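The compounds below may be only part of what the source reports. "The series", "measured", "known", "first", "only" and "open" are said of these compounds alone.

Of the compounds shown here, two sharing the same core have been measured in a functional assay, read by fluorescence and spectrophotometry, with a stated time of 1 h; on this read-out higher numbers stand for an effect only at larger amounts of compound and lower numbers for an effect already at smaller amounts. Compound 1 `CCCCCCS(=O)(=O)/C=C/c1ccc(O)c(O)c1` gives 7300 nM in this assay. Compound 2 `CCCCCCCCS(=O)(=O)/C=C/c1ccc(O)c(O)c1` gives 6400 nM in this assay. For the measured compounds named here, the single measured step, a 1.1-fold lower number from compound 1 to compound 2 (0.06 log units; within the scatter), comes from an ethyl in place of hydrogen on a saturated chain carbon, six bonds along the chain from a sulfonyl sulfur. Compound 2 and compound 1 lie within the scatter of each other, so on these numbers compound 2 cannot be set apart from compound 1.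

Compound 3 `CCCCCCCCCCS(=O)(=O)/C=C/c1ccc(O)c(O)c1` has not yet been measured. It differs from compound 2 by ethyl in place of hydrogen on a saturated chain carbon, eight bonds along the chain from a sulfonyl sulfur. Going by the values given here, the one step that bears on this change is the earlier one from compound 1 to compound 2, which stayed within the scatter, so no shift beyond the scatter is expected here either. Compound 3 is therefore estimated at 5500 nM in this assay, within a range from 2500 nM to 12000 nM. The expected step is a 1.2-fold lower number from compound 2 to compound 3 (0.07 log units; within the scatter).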

Compound 3, half-maximal effective concentration: 6800 nM
The estimate for compound 3 lay 1.2-fold (0.09 log units) below the measured number; low and high end bracket the measured number.
By their numbers in this assay, from the lowest: compounds 2, 3 and 1 (each within the scatter of the next).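

In this assay, a second lengthening at the chain end gives a 1.1-fold higher number from compound 2 to compound 3 (0.03 log units; within the scatter) and so also stays within the scatter. For the compounds shown here, the larger difference, butyl in place of hydrogen on a saturated chain carbon six bonds along the chain from a sulfonyl sulfur, gives a 1.1-fold lower number from compound 1 to compound 3 (0.03 log units; within the scatter) and is also within the scatter, so across compounds 1, 2 and 3 the added chain length shows no readable effect on this read-out, which the single earlier step could not show for a change this large. Nothing available explains why these numbers stay so close.

Still open, on these data alone, is whether a longer chain than that of compound 3 would move the number beyond the scatter. The same question stands for a chain ending in an amine or a carboxylic acid.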